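Swapping a bromo for a dimethylamino on the aniline

The compounds below may be only part of what the source reports. "The series", "measured", "known", "first", "only" and "open" are said of these compounds alone.

Of the compounds shown here, two have been measured in an ADME assay on Caco-2 cells (Homo sapiens) for permeability, in the apical to basolateral direction; on this read-out lower numbers stand for lower permeability and higher numbers for higher permeability. Compound 1, with the structure `CNC(=O)c1cc(Oc2ccc3sc(Nc4cccc(C(C)(C)C)c4)nc3c2)ccn1`, gives 10 10^-6 cm/s in this assay. Compound 2, with the structure `CNC(=O)c1cc(Oc2ccc3oc(Nc4ccc(Br)cc4)nc3c2)ccn1`, gives 10 10^-6 cm/s in this assay, which is level with compound 1 at the digits shown and within the usual scatter of repeated measurements, so the two cannot be told apart on these numbers.

Compound 3, with the structure `CNC(=O)c1cc(Oc2ccc3oc(Nc4ccc(N(C)C)cc4)nc3c2)ccn1`, has not yet been measured. It keeps the whole of compound 2 except for one change: dimethylamino in place of bromo on an aromatic carbon. Among the compounds with values here, no step between two measured compounds shows what this kind of change does to permeability here, so the expectation rests on the change itself and on the value of compound 2.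

For compound 3 the permeability in this assay is expected to be 7 10^-6 cm/s, with a range from 3 10^-6 cm/s to 14 10^-6 cm/s. The step of a 1.4-fold lower number from compound 2 to compound 3 (0.15 log units; within the scatter) is expected to be small and downward, close to the edge of the scatter rather than clearly beyond it.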

Compound 3, apparent permeability: 10 10^-6 cm/s
Compound 3: the middle estimate sits 1.4-fold (0.15 log units) below what was measured; low and high end bracket the measured number.
By their numbers in this assay, from the lowest: compounds 1, 2 and 3 (each within the scatter of the next).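

In this assay, the replacement of bromo by dimethylamino on an aromatic carbon, para to a large group, gives no change at the digits printed from compound 2 to compound 3 (within the scatter). Within the data shown here, this is the first step here between two measured compounds that differ in one place, and so the first direct reading of this position; the match between compound 1 and compound 2 could not give one, since those two differ in more than one place. Dimethylamino has more heavy atoms than bromo and brings a hydrogen-bond acceptor that bromo lacks, yet the read-out does not separate this pair, and no measurement at hand explains that outcome.

Going by these compounds, this single pair speaks only for these two groups at this one position, so it remains open whether a carboxylic acid, a primary amine or a longer chain ending in an amine would also leave the read-out unchanged here. On these data alone, it also remains open whether the same swap of bromo for dimethylamino would read the same way on the core of compound 1, or at another carbon of the same ring.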